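The compounds below may be only part of what the source reports. "The series", "measured", "known", "first", "only" and "open" are said of these compounds alone.

Measured in a functional assay on NCI-H460 cells (Homo sapiens) for cytotoxicity, read by sulforhodamine B assay; on this read-out lower numbers stand for stronger inhibition of growth and higher numbers for weaker inhibition of growth:
- compound 1 `COc1ccc(/C=N\NC(=S)NC(C)(C)CCC[C@](C)(O)[C@@H]2CC=C(C)CC2)cc1`: 5100 nM
- compound 2 `CC1=CC[C@@H]([C@@](C)(O)CCCC(C)(C)NC(=S)N/N=C\c2ccc(O)cc2)CC1`: 1460 nM
- compound 3 `CC1=CC[C@@H]([C@@](C)(O)CCCC(C)(C)NC(=S)N/N=C\c2ccc(N(C)C)cc2)CC1`: 19600 nM

Compound 3 has the highest number of the three, which makes it the weakest growth inhibitor in this small set. Compound 4 `CC1=CC[C@@H]([C@@](C)(O)CCCC(C)(C)NC(=S)N/N=C\c2cccc([N+](=O)[O-])c2)CC1` keeps the shared core and differs from compound 3 in one place: 3-nitrophenyl in place of 4-(dimethylamino)phenyl on a carbon with a double bond to nitrogen. In words, 3-nitrophenyl stands in place of 4-(dimethylamino)phenyl on a carbon with a double bond to nitrogen.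

Two measured steps bring in the dimethylamino group that compound 4 gives up: a 3.8-fold higher number from compound 1 to compound 3 (0.58 log units; beyond the scatter), a modest step from methoxy, and a 13-fold higher number from compound 2 to compound 3 (1.13 log units; beyond the scatter), a large step from hydroxy. Both raised the number, so losing that group is expected to lower it. Within the data shown here, no measured compound carries a nitro group, so the size of the change remains uncertain, and the modest step is the more cautious guide. The expected change is a 3.9-fold lower number from compound 3 to compound 4 (0.59 log units; beyond the scatter). For compound 4 the estimated value is 5000 nM, with an expected range from 1500 nM to 16000 nM.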

Compound 4, concentration for 50% growth inhibition: 8290 nM
For compound 4 the middle estimate is 1.7-fold (0.22 log units) below the measured one; the measured number falls inside the stated range.
By their numbers in this assay, from the lowest: compound 2; then compounds 1 and 4 (each within the scatter of the next); then compound 3.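

In this assay, the first nitro-bearing ring at this carbon with a double bond to nitrogen gives a 2.4-fold lower number from compound 3 to compound 4 (0.37 log units; beyond the scatter), so a ring without the dimethylamino group can lower the number even when it carries no hydroxy or methoxy group. Against the other rings, a 1.6-fold higher number from compound 1 to compound 4 (0.21 log units; within the scatter) lies within the scatter, so 3-nitrophenyl and 4-methoxyphenyl cannot be told apart here, whereas a 5.7-fold higher number from compound 2 to compound 4 (0.75 log units; beyond the scatter) leaves 4-hydroxyphenyl ahead of 3-nitrophenyl. No supporting measurement is available to explain these differences.

Each step replaces the whole ring group, so the effect of the nitro group itself cannot be separated from the effect of where it sits on the ring. From the compounds shown here alone, how a ring carrying a carboxylic acid or a primary amine would compare at this carbon remains open.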